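Removing the Benzyl Arm from a Weak Jurkat Inhibitor

The compounds below may be only part of what the source reports. "The series", "measured", "known", "first", "only" and "open" are said of these compounds alone.

Compound 2 `COC(=O)c1ccc(C2SCC(=O)N2c2ccc(N3CCN(Cc4cccc([N+](=O)[O-])c4)CC3)cn2)c(OC)c1` gives 37400 nM in a functional assay on Jurkat cells (Homo sapiens) for antiproliferative activity, read by MTT assay and trypan blue exclusion, with a stated time of 72 h (on this read-out lower numbers stand for stronger inhibition and higher numbers for weaker inhibition), the lowest of the two numbers measured; compound 1 `COC(=O)c1ccc(C2SCC(=O)N2c2ccc(N3CCN(Cc4cc(OC)c(OC)c(OC)c4)CC3)cn2)c(OC)c1` stands nearest with 41000 nM, and the step of a 1.1-fold lower number from compound 1 to compound 2 (0.04 log units; within the scatter) lies within the scatter. Compound 3 `COC(=O)c1ccc(C2SCC(=O)N2c2ccc(N3CCNCC3)cn2)c(OC)c1` differs from compound 2 by hydrogen in place of 3-nitrobenzyl on an amine nitrogen in a ring. For the measured compounds named here, the only measured step exchanged one group on that ring nitrogen for another and stayed within the scatter; no measured step removes the group entirely, so the expected step in this assay is a 1.1-fold higher number from compound 2 to compound 3 (0.03 log units; within the scatter), none beyond the scatter, with wide uncertainty. Compound 3 is estimated at 40000 nM, between 15000 nM and 110000 nM.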

Compound 3, half-maximal inhibitory concentration: 19300 nM
Beside the measured number, compound 3's estimate is 2.1-fold (0.32 log units) above it; the measured number falls inside the stated range.
By their numbers in this assay, from the lowest: compounds 3, 2 and 1 (each within the scatter of the next, the first and the last beyond it).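

In this assay, hydrogen in place of 3-nitrobenzyl on the amine nitrogen in the ring gives a 1.9-fold lower number from compound 2 to compound 3 (0.29 log units; within the scatter). The earlier step only exchanged one group on this nitrogen for another, whereas this one removes the group entirely, including its six-membered aromatic ring, and the number still stays within the scatter. From the compounds shown here alone, what a methyl group, an acetyl group or a longer chain on that nitrogen would give remains open. No measured evidence accounts for this result.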